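Isobutyl for Hydroxyethyl at the Amide-Bound Carbon

The compounds below may be only part of what the source reports. "The series", "measured", "known", "first", "only" and "open" are said of these compounds alone.

Among the measured compounds shown here, compound 2 `C[C@@H](O)[C@H](NC(=O)CN(c1nc(Cl)nc2[nH]cnc12)C1CC1)C(=O)O` gives the highest of the three numbers so far in a functional assay on the whole organism (Tail, strain ICR) with Mus musculus as the target, in the tail flick test, with a stated time of 150 min, at a dose of 25 umol/kg by the oral route (a lower number here means a weaker effect, a higher number a stronger effect of the compound at the dose given), with 24%, though its margin over the other two stays within the scatter. Compound 3 `CC(C)[C@H](NC(=O)CN(c1ncnc2c1ncn2C1CCCCO1)C1CC1)C(=O)OCc1ccccc1` gives 21.1% in this assay, and compound 1 `N=C(N)NCCC[C@H](NC(=O)CN(c1ncnc2c1ncn2C1CCCCO1)C1CC1)C(=O)OCc1ccccc1` gives 19.6%. Compound 4 `CC(C)C[C@H](NC(=O)CN(c1nc(Cl)nc2[nH]cnc12)C1CC1)C(=O)O` has not yet been measured; it differs from compound 2 in one place: isobutyl in place of 1-hydroxyethyl on a saturated chain carbon bound to an amide-type nitrogen and a carbonyl carbon.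

For the measured compounds named here, one measured step bears on this change. The step of a number 1.5 percentage points higher from compound 1 to compound 3 (within the scatter) exchanges the group at the same place, on a saturated chain carbon bound to an amide-type nitrogen and a carbonyl carbon, although on a different shared core, and it stays within the scatter. With a side group of this kind swapped there without any effect beyond the scatter, no step beyond the scatter is expected for the change at hand. The expected step reads a number 1 percentage points lower from compound 2 to compound 4 (within the scatter). Compound 4 is therefore estimated at 23% in this assay, within a range from 11% to 35%.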

Compound 4, a percentage reported as activity, at one dose (the size of the read-out at that dose, not a potency): 9.13%
Beside the measured number, compound 4's estimate is 13.9 percentage points above it; the measured number lies below the stated range.
By their numbers in this assay, from the lowest: compound 4; then compounds 1, 3 and 2 (each within the scatter of the next).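

Among the compounds shown here, the step of a number 14.9 percentage points lower from compound 2 to compound 4 (beyond the scatter) in this assay is the first change at this place, on a saturated chain carbon bound to an amide-type nitrogen and a carbonyl carbon, to lie beyond the scatter. The earlier step, a number 1.5 percentage points higher from compound 1 to compound 3 (within the scatter), lay within it and on a different core, so the position had looked tolerant; on the core shared by compound 2 and compound 4, it is not indifferent to the group it carries. No measurement given here accounts for the drop.

Going by these compounds, whether the drop follows from losing the oxygen-bearing 1-hydroxyethyl or from bringing in isobutyl stays open, as the two are exchanged together. A hydroxymethyl group, an aminoethyl group or a longer hydroxyalkyl chain at this place on the same core could begin to separate these two readings.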